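The source may hold more compounds than are shown below. What is called first, only, known or untested is meant among the compounds shown, and "the series" means these compounds.

Of the compounds shown here, two of a shared core have been measured in an assay on mitochondria from brain for inhibition of Amine oxidase [flavin-containing] A (Bos taurus), read by fluorescence; a higher number here means a weaker inhibitor, a lower number a stronger inhibitor. Compound 1 `Clc1ccc(-c2cc(-c3ccccc3)n[nH]2)cc1` carries a chloro and in this assay compound 1 gives 302 nM. Compound 2 `Cc1ccc(-c2cc(-c3ccccc3)[nH]n2)cc1` lacks that chloro and carries a methyl instead, and in this assay compound 2 gives 1510 nM, the highest of the two numbers shown; compound 1 sits at a lower number, and the gap between the two lies beyond the scatter. For the measured compounds named here, no step between two measured compounds that differ in one place is available here, so no directly comparable change has been quantified.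

Compound 3 `Cc1ccc(-c2cc(-c3ccc(Cl)cc3)[nH]n2)cc1` is the next compound to be measured. It differs from compound 2 in one place: chloro in place of hydrogen on an aromatic carbon. Compound 3 therefore keeps the methyl of compound 2 and takes on a chloro as compound 1 does. Since compound 1 gives 302 nM while compound 2 gives 1510 nM, the chloro-bearing compound stands at the lower number, and an improvement for compound 3 is expected. The step expected from adding the chloro is a 3.4-fold lower number from compound 2 to compound 3 (0.53 log units; beyond the scatter), a move to a lower number beyond the scatter. For compound 3 in this assay the estimate is 450 nM, with a range from 150 nM to 1300 nM.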

Compound 3, half-maximal inhibitory concentration: 3020 nM
For compound 3 the middle estimate is 6.7-fold (0.83 log units) below the measured one, outside the stated range (above it).
By their numbers in this assay, from the lowest: compound 1; then compounds 2 and 3 (each within the scatter of the next).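

In this assay, chloro in place of hydrogen on an aromatic carbon, para to a large group, gives a 2.0-fold higher number from compound 2 to compound 3 (0.30 log units; within the scatter), so with the methyl present this change cannot be told apart from the scatter and brings no measurable gain in inhibition. The other single change shows a clear effect: the added methyl gives a 10-fold higher number from compound 1 to compound 3 (1.00 log units; beyond the scatter), so with the chloro present, the methyl goes with a weaker inhibitor, and the low number of compound 1 cannot be credited to the chloro alone. No measurement is available that would explain this result.

The compounds shown leave open whether the methyl step would be of similar size without the chloro, as a compound with hydrogen at both of these places would show. They also leave open how other groups, such as fluoro, methoxy, an amine or a carboxylic acid, would read at the place now held by the chloro or by the methyl.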